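Swapping the aryl group on the shared core of three thiosemicarbazide pyrazolines

The compounds below may be only part of what the source reports. "The series", "measured", "known", "first", "only" and "open" are said of these compounds alone.

Three compounds sharing one core were tested in a functional assay on HCT-116 cells (Homo sapiens) for antiproliferative activity, read by MTT assay, with a stated time of 48 h; a lower number here means a stronger inhibitor of growth, a higher number a weaker inhibitor of growth. Compound 1 `S=C(Nc1ccccc1)N1N=C(c2ccc(Br)cc2)CC1c1ccc2c(c1)OCCO2` gives 32100 nM. Compound 2 `O=[N+]([O-])c1ccc(C2=NN(C(=S)Nc3ccccc3)C(c3ccc4c(c3)OCCO4)C2)cc1` reaches only the assay limit, > 200000 nM, which is a limit and not a number. Compound 3 `S=C(Nc1ccccc1)N1N=C(c2cccc(Cl)c2)CC1c1ccc2c(c1)OCCO2` gives 138000 nM; this is the highest of the two real numbers, the nearest being compound 1 with a 4.3-fold higher number from compound 1 to compound 3 (0.63 log units; beyond the scatter). Between compound 2 and compound 3 the step is an at least 1.4-fold lower number from compound 2 to compound 3 (0.16 log units; that floor lies within the scatter).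

Compound 4 `Cc1ccc(C2=NN(C(=S)Nc3ccccc3)C(c3ccc4c(c3)OCCO4)C2)cc1C` has not yet been measured. It differs from compound 3 in one place: 3,4-dimethylphenyl in place of 3-chlorophenyl on a carbon with a double bond to nitrogen. Two measured steps change the same aryl group on the carbon with a double bond to nitrogen. The step of a 4.3-fold higher number from compound 1 to compound 3 (0.63 log units; beyond the scatter) was modest, and an at least 6.2-fold higher number from compound 1 to compound 2 (0.79 log units; beyond the scatter) was at least modest. A similar swap in compound 4 is therefore expected to move this assay by a modest amount at most, in either direction, since the two steps do not point one way. The estimated step is a 1.7-fold lower number from compound 3 to compound 4 (0.24 log units; within the scatter), so compound 4 is expected to give about 80000 nM, between 25000 nM and 250000 nM.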

Compound 4, concentration for 50% growth inhibition: 144000 nM
Compound 4: middle estimate off by 1.8-fold (0.26 log units), on the low side, and the stated range covers the measured number.
By their numbers in this assay, from the lowest: compound 1; then compounds 3 and 4 (each within the scatter of the next). At a limit, above all of these: compound 2.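

In this assay, 3,4-dimethylphenyl in place of 3-chlorophenyl on a carbon with a double bond to nitrogen gives a 1.0-fold higher number from compound 3 to compound 4 (0.02 log units; within the scatter), so the two groups cannot be told apart at this carbon. The step of a 4.5-fold higher number from compound 1 to compound 4 (0.65 log units; beyond the scatter) shows that a second group, one that also carries a substituent in its 4 position, still falls short of the 4-bromophenyl of compound 1, so among the real numbers only compound 1 stands apart. Compound 2 sits at a limit and not at a number: the limit of > 200000 nM in this assay, at which 1 of the 4 values shown sits. The step of an at least 1.3-fold lower number from compound 2 to compound 4 (0.14 log units; that floor lies within the scatter) therefore cannot be read.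

The compounds shown leave open how a phenyl ring bearing an amine or a carboxylic acid would read at this carbon, and whether 4-chlorophenyl would match compound 1. Going by these compounds alone, only this one place changes, so the contribution of the rest of the shared core also stays open.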